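Methyl for hydrogen on the chain: compound 2 to compound 3

The source may report more compounds than this note shows. Statements on the series, on what has been measured and on what is new or still open speak of the compounds shown alone.

Working notes on the series in a functional assay on the whole organism (strain Swiss) with Mus musculus as the target, in the maximal electroshock model, with a stated time of 2 h, at a dose of 300 mg/kg by the intraperitoneal route; on this read-out higher numbers stand for a stronger effect at the one dose given and lower numbers for a weaker effect. Among the compounds with values here, compound 2 `CC(C(=O)N1CCN(c2ccccc2F)CC1)N1C(=O)CCC1=O` gives 25% in this assay and stands highest of the two numbers measured so far. The nearest is compound 1 `CCC(C(=O)N1CCN(c2cccc(F)c2)CC1)N1C(=O)CCC1=O`, which gives 0% in this assay, a gap beyond the usual scatter. Compound 3 `CCC(C(=O)N1CCN(c2ccccc2F)CC1)N1C(=O)CCC1=O` has not yet been measured. It differs from compound 2 by methyl in place of hydrogen on a saturated chain carbon, two bonds along the chain from an amide-type nitrogen in a ring and a carbonyl carbon. Within the data shown here, no measured pair shows this change by itself, so its size has to be guessed. Compound 1 also carries the longer chain, but it differs from compound 2 in more than one place, so its value cannot be read as the effect of this change alone. Still, with compound 1 at 0% the expectation is a step downward, estimated as a number 15 percentage points lower from compound 2 to compound 3 (beyond the scatter). Compound 3 is therefore expected to give about 10% in this assay, within a range from 0% to 30%.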

Compound 3, a percentage reported as activity, at one dose (the size of the read-out at that dose, not a potency): 0%
Estimate against measurement, compound 3: 10 percentage points above; measured number inside the range.
By their numbers in this assay, from the lowest: compounds 1 and 3 (each within the scatter of the next); then compound 2.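

In this assay, the change from methyl to ethyl on the saturated chain carbon can now be read by itself, and the read-out is a number 25 percentage points lower from compound 2 to compound 3 (beyond the scatter). With ethyl at this position, 2-fluorophenyl in place of 3-fluorophenyl on an amine nitrogen in a ring gives no change at the digits printed from compound 1 to compound 3 (within the scatter), so the position of the fluorine does not separate these two compounds at the one dose given. No measurement bears on why the read-out falls with this change.

The compounds shown leave open how hydrogen or a propyl group on this chain carbon would read. They also leave open whether 3-fluorophenyl in place of 2-fluorophenyl would matter with methyl on the chain, where compound 2 still gives a measurable read-out.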